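The compounds below may be only part of what the source reports. "The series", "measured", "known", "first", "only" and "open" are said of these compounds alone.

Measured so far in an ADME assay on microsomes from liver (Mus musculus) for metabolic stability, read by LC-MS, with a stated time of 10 min; a higher number here means that more of the compound is left, a lower number that less of the compound is left:
- compound 1 `CCN1CCN(c2cccc3c2C[C@H](CN(C)[C@H]2CCCc4cccnc42)NC3)CC1` gives 18.8%
- compound 2 `CN1CCN(c2cccc3c2C[C@H](CN(C)[C@H]2CCCc4cccnc42)NC3)CC1` gives 17%

Compound 2 holds the lower of the two numbers, but the step of a number 1.8 percentage points lower from compound 1 to compound 2 (within the scatter) is within the scatter, so the two compounds do not separate on this assay.

The next compound is compound 3 `CN(C[C@H]1Cc2c(cccc2N2C[C@H]3C[C@@H]2CN3)CN1)[C@H]1CCCc2cccnc21`. The change from compound 2 is a group of 7 heavy atoms (5 carbon, 2 nitrogen; 2 five-membered non-aromatic rings with 1 hetero atom each) in place of a group of 7 heavy atoms (5 carbon, 2 nitrogen; one six-membered non-aromatic ring with 2 hetero atoms), on an aromatic carbon.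

For the measured compounds named here, the one measured step, a number 1.8 percentage points lower from compound 1 to compound 2 (within the scatter), concerns a different change, hydrogen in place of methyl on a saturated chain carbon bound to an amine nitrogen in a ring, and was within the scatter. Going by the values given here, no measured step exchanges the whole group on the aromatic carbon, so nothing bears directly on the present change. The expected step of no change at the digits printed from compound 2 to compound 3 (within the scatter) is therefore centred on no change beyond the scatter, with a wide range to either side.

For compound 3 the expected value is 17%, with a range from 7% to 35%.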

Compound 3, percent of the compound remaining: 95.9%
For compound 3 the middle estimate is 78.9 percentage points below the measured one; the whole stated range lies below it.
By their numbers in this assay, from the lowest: compounds 2 and 1 (each within the scatter of the next); then compound 3.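

On the aromatic carbon, the group matters far more than the earlier pair suggested: in this assay, exchanging 4-methylpiperazin-1-yl for the bridged group of compound 3 gives a number 78.9 percentage points higher from compound 2 to compound 3 (beyond the scatter), and the same exchange against the larger group of compound 1 gives a number 77.1 percentage points higher from compound 1 to compound 3 (beyond the scatter). Compounds 1 and 2 differ only at the chain end of the piperazine ring and do not separate, whereas replacing the whole ring group shifts the number well beyond the scatter. Nothing measured here explains this shift.

The exchange alters the ring system, the hydrogen-bond donor count and the defined stereocentres together, so the compounds shown do not tell these apart. Open, going by these compounds, is whether piperazin-1-yl with a hydrogen on its ring nitrogen, or the bridged group carrying a methyl on that nitrogen, would fall nearer compound 2 or compound 3.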